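Carboxyalkyl chain trimming on the shared core

This account rests on a few compounds, and the source may have more. Where it says the series, first, only, none or still open, it means among the compounds named here.

Measured in a functional assay on CHO cells for antagonist activity at sphingosine 1-phosphate receptor 2 (Homo sapiens), read by GTPgammaS binding; on this read-out lower numbers stand for stronger inhibition and higher numbers for weaker inhibition:
- compound 1 `CCn1nc(CC(=O)Nc2ccc(OC(F)(F)F)c(Cl)c2)c2ccccc2c1=O`: 473 nM
- compound 2 `CCC(C(=O)O)c1nn(Cc2cn3cc(OCC4CC4)c(Cl)cc3n2)c2ccccc2c1=O`: 43 nM
- compound 3 `O=C(O)Cn1nc(Cc2nc3cc(F)c(OCC4CC4)cc3[nH]2)c2ccccc2c1=O`: 180 nM

Compound 2 stands lowest of the three numbers in this assay, with compound 3 the nearest and compound 1 the furthest, both gaps beyond the scatter. Going by the values given here, no pair of measured compounds differs in one place, so no single change has yet been isolated.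

Compound 4 `C[C@H](C(=O)O)c1nn(Cc2cn3cc(OCC4CC4)c(Cl)cc3n2)c2ccccc2c1=O` is the next analogue of compound 2. The change: 1-carboxyethyl in place of 1-carboxypropyl on an aromatic carbon.

The chain shortens by one carbon and the stereocentre becomes defined; nothing measured here speaks to either. The step is expected to stay within the scatter, and a 1.1-fold lower number from compound 2 to compound 4 (0.03 log units; within the scatter) is the estimate. Compound 4 is expected to give 40 nM, with a range from 12 nM to 130 nM.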

Compound 4, half-maximal inhibitory concentration in the sphingosine 1-phosphate receptor 2 assay: 16 nM
Compound 4: middle estimate off by 2.5-fold (0.40 log units), on the high side; low and high end bracket the measured number.
By their numbers in the sphingosine 1-phosphate receptor 2 assay, from the lowest: compound 4; then compound 2; then compound 3; then compound 1.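

Going by these compounds alone, this is the first one-place step, and it shows that this aromatic carbon responds to a small change in the chain: in the sphingosine 1-phosphate receptor 2 assay, 1-carboxyethyl in place of 1-carboxypropyl gives a 2.7-fold lower number from compound 2 to compound 4 (0.43 log units; beyond the scatter). In a physicochemical assay for lipophilicity, at pH 7.4 (a lower number here means a more polar compound, a higher number a more lipophilic compound), compound 2 gives 2.71 and compound 4 gives 2.39, so the number falls in both assays across this step. The step pairs the shorter chain with a defined stereocentre, and these two changes are not separated.

Still open, going by these compounds, are the mirror-image 1-carboxyethyl group and a tetrazole in place of the carboxylic acid.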